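Replacing a Side Group on a Shared Core

A few compounds are considered here, and "the series" means these few. Any claim that something is new, unique, unknown or untested is made for them only; others in the source may bear on it.

Of the compounds shown here, two with the same core have so far been measured in an ADME assay on HEp-2 cells (Homo sapiens) for cytotoxicity (on this read-out higher numbers stand for lower toxicity in this test and lower numbers for higher toxicity in this test), on this scale. Compound 1 `CC(C)CCn1c(Cn2c(=O)n(C(C)C)c3ccccc32)nc2ccc(C#N)cc21` gives 10000 nM in this test. Compound 2 `CNCc1ccc2nc(Cn3c(=O)n(C(C)C)c4ccccc43)n(CCC(C)C)c2c1` gives 4810 nM and holds the lower of the two numbers, so it is the more toxic of the pair here. Within the data shown here, the single measured step, a 2.1-fold lower number from compound 1 to compound 2 (0.32 log units; beyond the scatter), is modest.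

The next molecule is compound 3 `CC(C)CCn1c(Cn2c(=O)n(C(C)C)c3ccccc32)nc2ccc(C(=O)O)cc21`, and the change from compound 2 is carboxy in place of (methylamino)methyl on an aromatic carbon. Among the measured compounds shown here, only that one measured step bears on this change, since it involves the same position. Compound 3 gives up the (methylamino)methyl group that compound 2 alone carries, so its number may return towards that of compound 1 at 10000 nM. For the measured compounds named here, no carboxy compound has been measured yet, which makes this a weak guide. The expected change, a 2.1-fold higher number from compound 2 to compound 3 (0.32 log units; beyond the scatter), is a rise of about the same modest size. For compound 3 the estimate is 10000 nM with an expected range from 5000 nM to 30000 nM at its ends.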

Compound 3, half-maximal cytotoxic concentration: 125000 nM
Compound 3: middle estimate off by 13-fold (1.10 log units), on the low side, outside the stated range (above it).
By their numbers in this assay, from the lowest: compound 2; then compound 1; then compound 3.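

Among these compounds, at this aromatic carbon, the choice of group can matter far more in this assay than the earlier compounds showed: the swap to (methylamino)methyl gave only a 2.1-fold lower number from compound 1 to compound 2 (0.32 log units; beyond the scatter), whereas carboxy gives a 26-fold higher number from compound 2 to compound 3 (1.41 log units; beyond the scatter), and in place of cyano it gives a 13-fold higher number from compound 1 to compound 3 (1.10 log units; beyond the scatter). Both new steps are large and beyond the scatter, so compound 3 holds the highest number of the three and is the least toxic in this test. Carboxy and (methylamino)methyl match in their counts of heavy atoms, hydrogen-bond donors and hydrogen-bond acceptors, so those counts do not separate compound 2 from compound 3, and no measurement available here accounts for the jump.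

The compounds shown leave open whether the high number belongs to carboxy itself or would also appear with a close relative on the same aromatic carbon, such as a methyl ester or a primary amide. They also leave open whether a simple amino group or a hydroxymethyl group there would give a number nearer to that of compound 2 or to that of compound 1.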